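The source may report more compounds than this note shows. Statements on the series, on what has been measured and on what is new or still open speak of the compounds shown alone.

In a functional assay on HCT-116 cells (Homo sapiens) for inhibition, read by CCK-8 assay, with a stated time of 48 h (on this read-out lower numbers stand for stronger inhibition and higher numbers for weaker inhibition), compound 1 `COc1ccc(CN(C(=O)CSC(=S)N2CCN(C)CC2)c2cc(OC)c(OC)c(OC)c2)cc1` gives 2640 nM. This lies within the scatter of compound 2 `COc1ccc(CN(C(=O)CSC(=S)N2CCN(C(C)=O)CC2)c2cc(OC)c(OC)c(OC)c2)cc1` at 1370 nM and is clearly lower than compound 3 `COc1ccc(CN(C(=O)CSC(=S)N2CCc3ccccc32)c2cc(OC)c(OC)c(OC)c2)cc1` at 7710 nM. Compound 4 `COc1ccc(CN(C(=O)CSC(=S)N2CCc3cc(OC)ccc32)c2cc(OC)c(OC)c(OC)c2)cc1` differs from compound 1 by 5-methoxy-2,3-dihydro-1H-indol-1-yl in place of 4-methylpiperazin-1-yl on a thiocarbonyl carbon. The closest measured change is a 2.9-fold higher number from compound 1 to compound 3 (0.47 log units; beyond the scatter), where 2,3-dihydro-1H-indol-1-yl enters on the same thiocarbonyl carbon. a 5.6-fold higher number from compound 2 to compound 3 (0.75 log units; beyond the scatter) runs in the same direction. Going by the values given here, no measured pair isolates the 5-methoxy group, so a step toward a higher number, no larger than the first of these, is expected in this assay. The expected change is a 1.5-fold higher number from compound 1 to compound 4 (0.18 log units; within the scatter). Compound 4 is estimated at 4000 nM, within a range of 1000 nM to 12000 nM.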

Compound 4, half-maximal inhibitory concentration: 9810 nM
Beside the measured number, compound 4's estimate is 2.5-fold (0.39 log units) below it; low and high end bracket the measured number.
By their numbers in this assay, from the lowest: compounds 2 and 1 (each within the scatter of the next); then compounds 3 and 4 (each within the scatter of the next).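

Methoxy in place of hydrogen on an aromatic carbon gives a 1.3-fold higher number from compound 3 to compound 4 (0.10 log units; within the scatter) in this assay and so does not separate these two compounds. 5-Methoxy-2,3-dihydro-1H-indol-1-yl on the thiocarbonyl carbon gives a 3.7-fold higher number from compound 1 to compound 4 (0.57 log units; beyond the scatter) and a 7.2-fold higher number from compound 2 to compound 4 (0.85 log units; beyond the scatter) and so stays on the higher side of both piperazine groups, as 2,3-dihydro-1H-indol-1-yl does. Nothing at hand explains these differences. From the compounds shown here alone, whether a chloro group or a carboxylic acid in place of that methoxy would move the number stays open, as does how morpholin-4-yl on the thiocarbonyl carbon would compare with the piperazine groups.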